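The compounds below may be only part of what the source reports. "The series", "measured", "known", "first", "only" and "open" are said of these compounds alone.

Measured so far:
compound 1 `CC(c1ccc(-c2ccccc2)c(F)c1)c1nnc2n1N=C(c1ccc(Cl)cc1Cl)CS2` in a functional assay on Huh-7 cells (Homo sapiens) for inhibition, read by sulforhodamine B assay, with a stated time of 72 h; a higher number here means a weaker inhibitor, a lower number a stronger inhibitor: 3700 nM
compound 2 `COc1ccc2cc(C(C)c3nnc4n3N=C(c3ccc(F)cc3)CS4)ccc2c1` in this assay: 7000 nM

Compound 1 has the lower of the two numbers, but compound 2 sits close enough that the two values are within the scatter of this kind of measurement, so neither can be called stronger. Compound 3 `Cc1ccc(C2=Nn3c(nnc3C(C)c3ccc(-c4ccccc4)c(F)c3)SC2)cc1` differs from compound 1 in one place: 4-methylphenyl in place of 2,4-dichlorophenyl on a carbon with a double bond to nitrogen. Nothing measured shows what this exchange does. The expectation is a small weakening, a 1.6-fold higher number from compound 1 to compound 3 (0.21 log units; within the scatter), not clearly beyond the scatter. Compound 3 is therefore expected to give about 6000 nM, in a range from 2000 nM to 18000 nM.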

Compound 3, half-maximal inhibitory concentration: 7200 nM
Estimate against measurement, compound 3: 1.2-fold (0.08 log units) below; the measured number falls inside the stated range.
By their numbers in this assay, from the lowest: compounds 1, 2 and 3 (each within the scatter of the next).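

In this assay, 4-methylphenyl in place of 2,4-dichlorophenyl on a carbon with a double bond to nitrogen gives a 1.9-fold higher number from compound 1 to compound 3 (0.29 log units; within the scatter), so compound 1 and compound 3 cannot be told apart. At this position, then, a phenyl ring carrying a single methyl group and one carrying two chlorine atoms give numbers that this assay does not separate. Nothing available speaks to the reason for this result. Still open, as far as these compounds go, is what a group other than a substituted phenyl ring, such as an amine or a carboxylic acid, would give on this carbon.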